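From 4-methylphenyl to 4-fluorophenyl on a sulfonamide nitrogen

The source may report more compounds than this note shows. Statements on the series, on what has been measured and on what is new or still open speak of the compounds shown alone.

Within the data shown here, in a functional assay on M21 cells (Homo sapiens) for antiproliferative activity, read by sulforhodamine B assay, with a stated time of 48 h (on this read-out higher numbers stand for weaker inhibition and lower numbers for stronger inhibition), compound 2 (`Cc1ccc(NS(=O)(=O)c2ccc(N3CCNC3=O)cc2)cc1`) gives 260 nM, the higher of the two numbers measured so far, while compound 1 (`Cc1cccc(NS(=O)(=O)c2ccc(N3CCNC3=O)cc2)c1`) gives 69 nM. Compound 3 (`O=C1NCCN1c1ccc(S(=O)(=O)Nc2ccc(F)cc2)cc1`) differs from compound 2 by fluoro in place of methyl on an aromatic carbon, para to a large group: fluoro in place of methyl on an aromatic carbon. Among the measured compounds shown here, only one measured step bears on this position, a 3.8-fold higher number from compound 1 to compound 2 (0.58 log units; beyond the scatter), a modest change beyond the scatter. For the measured compounds named here, that step exchanges 3-methylphenyl for 4-methylphenyl, so it shows that the ring substitution matters in this assay, but no measurement yet covers fluoro. No clear direction can therefore be drawn, and no change beyond the scatter is expected. The expected step is a 1.3-fold higher number from compound 2 to compound 3 (0.13 log units; within the scatter). For compound 3 the estimated value is 350 nM, with an expected range of 110 nM to 1100 nM.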

Compound 3, half-maximal inhibitory concentration: 230 nM
Compound 3: middle estimate off by 1.5-fold (0.18 log units), on the high side; measured number inside the range.
By their numbers in this assay, from the lowest: compound 1; then compounds 3 and 2 (each within the scatter of the next).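

Fluoro in place of methyl on an aromatic carbon, para to a large group, gives a 1.1-fold lower number from compound 2 to compound 3 (0.05 log units; within the scatter) in this assay and so leaves the number within the scatter. Among these compounds, this is the first exchange at this position with the ring placement held fixed, and it shows that 4-fluorophenyl and 4-methylphenyl cannot be told apart here. The step of a 3.3-fold higher number from compound 1 to compound 3 (0.52 log units; beyond the scatter) is beyond the scatter, so compound 1, with its 3-methylphenyl, keeps the lowest number of the three. No measurement at hand explains why the two groups read alike. On these data alone, what stays open is whether a 3-fluorophenyl group would match the 3-methylphenyl of compound 1. Also open, as far as these compounds go, is how a methoxy group, an amine or a carboxylic acid would read in the place of the fluoro.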